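Notes on the benzylic group: compound 2 to compound 3

This account rests on a few compounds, and the source may have more. Where it says the series, first, only, none or still open, it means among the compounds named here.

Measured in a functional assay on HCT-116 cells (Homo sapiens) for inhibition, read by MTT assay, with a stated time of 72 h; on this read-out lower numbers stand for stronger inhibition and higher numbers for weaker inhibition
- Compound 1 `Cc1cc(C)cc(CN2CCc3ncn(COCc4ccccc4)c3/C(=C/c3ccccc3)C2=O)c1` gives 6230 nM
- Compound 2 `Cc1ccccc1CN1CCc2ncn(COCc3ccccc3)c2/C(=C/c2ccccc2)C1=O` gives 24700 nM

Within the data shown here, compound 2 has the higher of the two numbers so far. From compound 2 to compound 3 `O=C1/C(=C\c2ccccc2)c2c(ncn2COCc2ccccc2)CCN1Cc1ccc2ccccc2c1` the change is naphthalen-2-yl in place of 2-methylphenyl on a saturated chain carbon bound to an amide-type nitrogen in a ring and it puts naphthalen-2-yl in place of 2-methylphenyl on a saturated chain carbon bound to an amide-type nitrogen in a ring. Among the measured compounds shown here, one measured step bears on this place, namely a 4.0-fold higher number from compound 1 to compound 2 (0.60 log units; beyond the scatter) and it is modest. It shows that the number moves with the group here, but gives no rule for naphthalen-2-yl. For the measured compounds named here, with compound 2 at 24700 nM as the higher value, a modest move to a lower number is expected in this assay and no larger than that step. The estimated step is a 2.5-fold lower number from compound 2 to compound 3 (0.39 log units; beyond the scatter) with wide uncertainty. Compound 3 is expected at 10000 nM within an estimated range from 3000 nM to 30000 nM for now.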

Compound 3, half-maximal inhibitory concentration: 19400 nM
Beside the measured number, compound 3's estimate is 1.9-fold (0.29 log units) below it; the range from low to high includes it.
By their numbers in this assay, from the lowest: compound 1; then compounds 3 and 2 (each within the scatter of the next).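

In this assay the exchange of 2-methylphenyl for naphthalen-2-yl gives a 1.3-fold lower number from compound 2 to compound 3 (0.10 log units; within the scatter) and so a second six-membered aromatic ring of carbon only, on this saturated chain carbon, brings no readable separation between these two compounds. Set against 3,5-dimethylphenyl, the same group gives a 3.1-fold higher number from compound 1 to compound 3 (0.49 log units; beyond the scatter) and this leaves compound 1 alone at the low end of the three with 6230 nM as its value. No measured evidence on the series accounts for these numbers.

The aryl groups shown on this carbon are all built of carbon only, so it stays open how a pyridine ring, an amine or a carboxylic acid would read here. Equally open, as far as these compounds go, is how an unsubstituted phenyl group on the same carbon would read against compound 1.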